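Fluoro in place of phenyl: notes on the series

A few compounds are considered here, and "the series" means these few. Any claim that something is new, unique, unknown or untested is made for them only; others in the source may bear on it.

- compound 1 `O=C(CCCCCCNC(=O)C(O)(O)C(F)(F)F)Nc1nc2ccccc2o1`: 3450 nM
- compound 2 `O=C(CCCCCCNC(=O)C(O)(O)C(F)(F)F)Nc1ccccc1`: 9140 nM
- compound 3 `O=C(CCCCCCNC(=O)C(O)(O)C(F)(F)F)Nc1ccc(-c2ccccc2)cc1`: 4730 nM

In a functional assay on HCT-116 cells (Homo sapiens) for inhibition, read by colorimetric assay, with a stated time of 3 days (on this read-out lower numbers stand for stronger inhibition and higher numbers for weaker inhibition), compound 3 at 4730 nM lies within the scatter of both compound 1 and compound 2. Next is compound 4 `O=C(CCCCCCNC(=O)C(O)(O)C(F)(F)F)Nc1ccc(F)cc1`: fluoro in place of phenyl on an aromatic carbon. The closest measured step is a 1.9-fold lower number from compound 2 to compound 3 (0.29 log units; within the scatter), which adds the same phenyl. The step of a 2.6-fold higher number from compound 1 to compound 2 (0.42 log units; beyond the scatter) concerns the group on the amide-type nitrogen and bears only loosely. Within the data shown here, no fluoro compound has been measured. Losing the phenyl should therefore roughly reverse the first step, giving a higher number, without going beyond the scatter. The expected step is a 1.7-fold higher number from compound 3 to compound 4 (0.23 log units; within the scatter). Compound 4 is estimated at 8000 nM, with an expected range of 4000 nM to 16000 nM.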

Compound 4, half-maximal inhibitory concentration: 7570 nM
Beside the measured number, compound 4's estimate is 1.1-fold (0.02 log units) above it; low and high end bracket the measured number.
By their numbers in this assay, from the lowest: compounds 1, 3, 4 and 2 (each within the scatter of the next, the first and the last beyond it).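

In this assay hydrogen, fluoro and phenyl on this aromatic carbon are not told apart: fluoro for phenyl gives a 1.6-fold higher number from compound 3 to compound 4 (0.20 log units; within the scatter) and fluoro for hydrogen gives a 1.2-fold lower number from compound 2 to compound 4 (0.08 log units; within the scatter) on the same carbon. On the amide-type nitrogen, 4-fluorophenyl for 1,3-benzoxazol-2-yl gives a 2.2-fold higher number from compound 1 to compound 4 (0.34 log units; beyond the scatter) and so remains a modest difference. No supporting data on hand explain these steps.

On these data alone, whether an amine or a carboxylic acid on this aromatic carbon would move the number beyond the scatter remains open. So does the effect of a longer chain in the shared core.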